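Aryl Exchange on the Ring Amide Nitrogen

The compounds below may be only part of what the source reports. "The series", "measured", "known", "first", "only" and "open" are said of these compounds alone.

Compound 3 `COc1ccc(N2C(=O)[C@H]3[C@H](ON4[C@@H]3C(=O)N(C)[C@@]43C[C@H](C)CC[C@H]3C(C)C)C2=O)cc1` stands second highest of the three numbers in a functional assay, read by spectrophotometry, with a stated time of 2 h, tested at 3 mg/mL (a lower number here means a weaker effect, a higher number a stronger effect of the compound at the concentration tested), giving 67.7%. Compound 2 `CC(C)[C@@H]1CC[C@@H](C)C[C@@]12N(C)C(=O)[C@@H]1[C@H]3C(=O)N(c4ccc(Cl)cc4)C(=O)[C@H]3ON12` gives 73.3%, and a number 5.6 percentage points lower from compound 2 to compound 3 (within the scatter). Compound 1 `CC(C)[C@@H]1CC[C@@H](C)C[C@@]12N(C)C(=O)[C@@H]1[C@H]3C(=O)NC(=O)[C@H]3ON12` gives 47.3%, so that a number 20.4 percentage points higher from compound 1 to compound 3 (beyond the scatter). Compound 4 `Cc1cccc(N2C(=O)[C@H]3[C@H](ON4[C@@H]3C(=O)N(C)[C@@]43C[C@H](C)CC[C@H]3C(C)C)C2=O)c1` is not yet measured; its change from compound 3 is 3-methylphenyl in place of 4-methoxyphenyl on an amide-type nitrogen in a ring. Among the compounds with values here, two steps bear on this: a number 26 percentage points higher from compound 1 to compound 2 (beyond the scatter) and a number 20.4 percentage points higher from compound 1 to compound 3 (beyond the scatter) both follow from placing an aryl group on that nitrogen, whereas a number 5.6 percentage points lower from compound 2 to compound 3 (within the scatter), an exchange of one aryl substituent for another, stays inside the scatter. For compound 4 the expectation is therefore no step beyond the scatter, a number 0.3 percentage points higher from compound 3 to compound 4 (within the scatter). For compound 4 the estimate is 68%, within 56% to 80%.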

Compound 4, a percentage reported as activity, at one concentration (the size of the read-out at that concentration, not a potency): 65.8%
Compound 4: the middle estimate sits 2.2 percentage points above what was measured; the measured number falls inside the stated range.
By their numbers in this assay, from the lowest: compound 1; then compounds 4, 3 and 2 (each within the scatter of the next).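

In this assay, 3-methylphenyl in place of 4-methoxyphenyl (a number 1.9 percentage points lower from compound 3 to compound 4 (within the scatter)) or of 4-chlorophenyl (a number 7.5 percentage points lower from compound 2 to compound 4 (within the scatter)) leaves the read-out within the scatter, so this position tolerates an aryl group whose substituent has no hydrogen-bond acceptor and stands on a different ring carbon. The gain over the amide hydrogen (a number 18.5 percentage points higher from compound 1 to compound 4 (beyond the scatter)) now holds for three aryl groups. No supporting evidence explains these results.

As far as these compounds go, whether the gain requires an aryl ring remains open, and a longer alkyl chain on that nitrogen would address this. From the compounds shown here alone, the effect of an amine or carboxylic acid on the aryl ring also remains unknown.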